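This account rests on a few compounds, and the source may have more. Where it says the series, first, only, none or still open, it means among the compounds named here.

Of the compounds shown here, three built on one shared core have been measured in a functional assay on the whole organism for inhibition, with Rattus norvegicus as the target, at a dose of 30 mg/kg; a lower number here means less inhibition, a higher number more inhibition at the dose given (going by the name of the read-out). Compound 1 `Clc1ccc(-c2nc3ncccc3o2)cc1` gives 24%, the highest of the three numbers. Compound 2 `COc1ccc(-c2nc3ncccc3o2)cc1` gives 14%, and compound 3 `FC(F)(F)Oc1ccc(-c2nc3ncccc3o2)cc1` gives 0%. The step of a number 10 percentage points lower from compound 1 to compound 2 (within the scatter) lies within the scatter, so compound 1 and compound 2 cannot be told apart, while a number 24 percentage points lower from compound 1 to compound 3 (beyond the scatter) and a number 14 percentage points lower from compound 2 to compound 3 (beyond the scatter) both lie beyond it.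

Compound 4 `Fc1cc(Cl)ccc1-c1nc2ncccc2o1` keeps the chloro group of compound 1 and differs from it in one place: fluoro in place of hydrogen on an aromatic carbon. Among the measured compounds shown here, none of the measured steps is of this kind. Each of them replaced the chloro group itself, and all three shifted the inhibition by modest amounts, with only the changes to trifluoromethoxy reaching beyond the scatter. Adding a fluoro group while the chloro group stays is a change the measured compounds do not cover, so no step beyond the scatter is expected in either direction in this assay, and the uncertainty is wide.

Compound 4 is therefore expected to give about 24%, between 8% and 40%. That estimate means a step of no change at the digits printed from compound 1 to compound 4 (within the scatter), expected to stay within the scatter.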

Compound 4, a percentage reported as inhibition, in the whole organism at one dose (the size of the read-out at that dose, not a potency): 19%
Estimate against measurement, compound 4: 5 percentage points above; measured number inside the range.
By their numbers in this assay, from the lowest: compound 3; then compounds 2, 4 and 1 (each within the scatter of the next).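

In this assay, placing fluoro in place of hydrogen on an aromatic carbon, ortho to a group of 9 heavy atoms and meta to a chloro group, gives a number 5 percentage points lower from compound 1 to compound 4 (within the scatter), so compound 1 and compound 4 cannot be told apart. The earlier steps shown here all replaced the chloro group itself, whereas this one leaves that group in place and changes a different carbon of the same ring, showing that a single fluoro group here, with the chloro group kept, produces no step beyond the scatter. Nothing available bears on why this step stays so small.

The compounds shown leave open how this position responds to an amine or a carboxylic acid in place of the hydrogen, which would test it with groups quite unlike fluoro. They also leave open whether a fluoro group here would leave the number just as unmoved alongside the methoxy group of compound 2 or the trifluoromethoxy group of compound 3.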